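Efficacy in the series: aryl versus cyclohexyl on the ring oxygen

The source may report more compounds than this note shows. Statements on the series, on what has been measured and on what is new or still open speak of the compounds shown alone.

Measured compounds:
compound 1, `N[C@@H](COP(=O)(O)OCCCOC(=O)CCc1ccccc1OCc1cccc(OC2CCCCC2)c1)C(=O)O`, 0.11
compound 2, `N[C@@H](COP(=O)(O)OCCCOC(=O)CCc1ccccc1OCc1cccc(Oc2ccc(F)cc2)c1)C(=O)O`, 0.66

Going by the values given here, in an assay on cells for activation of probable G-protein coupled receptor 34 (Mus musculus), with a stated time of 1 h (a higher number here means a larger maximal response, a lower number a smaller maximal response), compound 2 gives the higher of the two numbers; its nearest neighbour is compound 1, and the one step computed between measured compounds is a number 0.55 higher from compound 1 to compound 2 (beyond the scatter). Compound 3, `CC(C)(C)c1cccc(Oc2cccc(COc3ccccc3CCC(=O)OCCCOP(=O)(O)OC[C@H](N)C(=O)O)c2)c1`, is not yet measured in this assay. Against compound 2 it carries 3-(tert-butyl)phenyl in place of 4-fluorophenyl on an oxygen on an aromatic ring.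

Among the compounds with values here, only the step from compound 1 to compound 2 bears on this change, and only partly: that step swapped a saturated ring for an aromatic one on the oxygen and was large, whereas compound 3 keeps an aromatic ring there and alters only what that ring carries. Nothing measured tells how a tert-butyl on the ring, or loss of the fluorine, moves the maximal response. The expectation is therefore that compound 3 stays closer to compound 2 than to compound 1, with a step of a number 0.060 lower from compound 2 to compound 3 (within the scatter), not beyond the scatter in either direction. Compound 3 is estimated at 0.6, within 0.3 to 0.9.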

Compound 3, intrinsic activity: the largest response reached, as a fraction of the reference agonist's: 0.39
Estimate against measurement, compound 3: 0.21 above; the measured number falls inside the stated range.
By their numbers in this assay, from the lowest: compound 1; then compound 3; then compound 2.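

In this assay, the aromatic ring on the oxygen does not by itself fix the maximal response: 3-(tert-butyl)phenyl in place of 4-fluorophenyl gives a number 0.27 lower from compound 2 to compound 3 (beyond the scatter), so what the ring carries matters as well. Against the saturated ring, 3-(tert-butyl)phenyl in place of cyclohexyl gives a number 0.28 higher from compound 1 to compound 3 (beyond the scatter), which means both aromatic groups shown lie above cyclohexyl, and none of the three compounds goes against that order, though the size of the gain depends on the group. No measurement at hand offers an explanation for either step.

The step from 4-fluorophenyl to 3-(tert-butyl)phenyl changes both the substituent and where it sits on the ring, as the two names show, and the compounds shown cannot separate these two changes. On these data alone, it remains open where a plain phenyl on the oxygen would fall, and whether a ring carrying a methoxy group or a nitrile would stay near the response of compound 2 or drop towards that of compound 1.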